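Restoring the Amino Link Beside a Chloro-Trifluoromethyl Ring

This account rests on a few compounds, and the source may have more. Where it says the series, first, only, none or still open, it means among the compounds named here.

Compound 1, `COc1cc(-c2nn(-c3cccc(NC(=O)Nc4cc(C(F)(F)F)cc(C(F)(F)F)c4)c3)cc2-c2ccncc2)ccc1Cl`, and compound 2, `COc1cc(-c2nn(-c3cccc(NC(=O)c4cccc(C(F)(F)F)c4)c3)cc2-c2ccncc2)ccc1Cl`, share one core and differ in the link to the carbonyl and in the terminal aryl ring. In a functional assay on SNB-19 cells (Homo sapiens) for inhibition, read by sulforhodamine B assay, with a stated time of 48 h (a higher number here means a weaker inhibitor of growth, a lower number a stronger inhibitor of growth), compound 1 gives 3670 nM. In this assay, on these data alone, compound 2 reaches only > 50000 nM, which is a limit of the assay and not a number, so its true position is unknown. Compound 2 thus sits at the limit of > 50000 nM in this assay, at which 1 of the 2 values shown sits. Compound 3, `COc1cc(-c2nn(-c3cccc(NC(=O)Nc4ccc(Cl)c(C(F)(F)F)c4)c3)cc2-c2ccncc2)ccc1Cl`, carries a changed terminal group: (4-chloro-3-(trifluoromethyl)phenyl)amino in place of 3-(trifluoromethyl)phenyl on a carbonyl carbon. Within the data shown here, no measured step joins compound 2 and compound 3, so the size of the change in this assay is not known from data. Because compound 1 gives 3670 nM while also bearing an amino link on its carbonyl, a step well beyond the scatter toward stronger growth inhibition is expected. Compound 3 is estimated at 5000 nM, with a likely range from 1500 nM to 20000 nM. The expected step is an at least 10-fold lower number from compound 2 to compound 3 (1.00 log units; beyond the scatter).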

Compound 3, concentration for total growth inhibition: 9240 nM
Compound 3: middle estimate off by 1.8-fold (0.27 log units), on the low side, within the range that was stated.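

The position on the carbonyl carbon now has a measured response in this assay: (4-chloro-3-(trifluoromethyl)phenyl)amino in place of 3-(trifluoromethyl)phenyl gives an at least 5.4-fold lower number from compound 2 to compound 3 (0.73 log units; beyond the scatter). That step is a bound and not an exact size, because compound 2 stands at a limit of the assay and not at a number: the limit of > 50000 nM in this assay, at which 1 of the 3 values shown sits. The change brings in the amino nitrogen, with its hydrogen-bond donor, and the chlorine together, so the step belongs to the two as a pair and cannot be divided between them.

The compounds shown leave open how much of the step follows the amino nitrogen alone and how much follows the chlorine alone. They also leave open how the value would move with an oxygen or a methylene in place of that nitrogen, or with a fluorine or a methyl in place of the chlorine.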